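The compounds below may be only part of what the source reports. "The series", "measured", "known", "first", "only" and "open" are said of these compounds alone.

Measured in a functional assay on M21 cells (Homo sapiens) for antiproliferative activity, read by sulforhodamine B assay, with a stated time of 48 h; on this read-out lower numbers stand for stronger inhibition and higher numbers for weaker inhibition:
- compound 1 `CCCCc1ccc(NS(=O)(=O)c2ccc(N3CCNC3=O)cc2)cc1`: 450 nM
- compound 2 `O=C1NCCN1c1ccc(S(=O)(=O)Nc2ccccc2)cc1`: 200 nM
- compound 3 `O=C1NCCN1c1ccc(S(=O)(=O)Nc2ccc(OC(F)F)cc2)cc1`: 410 nM

Compound 3 sits with compound 1 at the higher end of these three numbers, and compound 2 stands apart from both. The data show a 1.1-fold lower number from compound 1 to compound 3 (0.04 log units; within the scatter), and also a 2.1-fold higher number from compound 2 to compound 3 (0.31 log units; beyond the scatter).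

The next compound to be tested is compound 4 `CCCCCc1ccc(NS(=O)(=O)c2ccc(N3CCNC3=O)cc2)cc1`, which has pentyl in place of difluoromethoxy on an aromatic carbon, para to a large group: pentyl in place of difluoromethoxy on an aromatic carbon. Within the data shown here, no measured compound carries pentyl, so the closest guide is compound 1, which carries butyl at that place. Among the measured compounds shown here, two steps bear on the change. The exchange of butyl for difluoromethoxy gave a 1.1-fold lower number from compound 1 to compound 3 (0.04 log units; within the scatter), so the two groups could not be told apart here. Removing butyl gave a modest change, a 2.3-fold lower number from compound 1 to compound 2 (0.35 log units; beyond the scatter), so compounds 1 and 3 both carry a group and both give higher numbers than compound 2, which has none. Pentyl should therefore behave much like butyl, and no step beyond the scatter is expected, with at most a slight rise. The expected step is a 1.2-fold higher number from compound 3 to compound 4 (0.09 log units; within the scatter). For compound 4 the estimated value is 500 nM, with an expected range from 220 nM to 1100 nM.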

Compound 4, half-maximal inhibitory concentration: 870 nM
Estimate against measurement, compound 4: 1.7-fold (0.24 log units) below; measured number inside the range.
By their numbers in this assay, from the lowest: compound 2; then compounds 3, 1 and 4 (each within the scatter of the next, the first and the last beyond it).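

In this assay, pentyl in place of difluoromethoxy on the aromatic carbon gives a 2.1-fold higher number from compound 3 to compound 4 (0.33 log units; beyond the scatter), so these two groups can be told apart at this place, although butyl and difluoromethoxy could not. Yet the change from the butyl chain to the pentyl chain, methyl in place of hydrogen on a saturated chain carbon, gives a 1.9-fold higher number from compound 1 to compound 4 (0.29 log units; within the scatter), which stays within the scatter, so this extension alone shows no clear effect and compound 1 and compound 4 cannot be told apart. Against compound 2, which carries only hydrogen at this place, pentyl gives a 4.4-fold higher number from compound 2 to compound 4 (0.64 log units; beyond the scatter), and among these four compounds, every one with a group at this place (butyl, difluoromethoxy or pentyl) gives a higher number than compound 2, with none going against this.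

Nothing measured here explains why these numbers differ.
From the compounds shown here alone, it also remains open how a shorter chain such as ethyl, a longer chain such as hexyl, or an amine or a carboxylic acid at this place would compare with hydrogen in compound 2.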